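Methyl on the sulfonyl ring of a thiadiazole sulfonamide

The source may report more compounds than this note shows. Statements on the series, on what has been measured and on what is new or still open speak of the compounds shown alone.

Measured compounds:
compound 1, `O=S(=O)(Nc1nnc(SCc2ccccc2)s1)c1ccccc1`: 65%
compound 2, `O=S(=O)(Nc1nnc(SCc2ccc(Cl)cc2)s1)c1ccccc1`: 68%

Of the compounds shown here, two have been tested in a functional assay on MCF7 cells (Homo sapiens) for cytotoxicity, tested at 250 uM; on this read-out lower numbers stand for a stronger effect and higher numbers for a weaker effect at the one concentration tested. Compound 1, `O=S(=O)(Nc1nnc(SCc2ccccc2)s1)c1ccccc1`, gives 65% in this assay. Compound 2, `O=S(=O)(Nc1nnc(SCc2ccc(Cl)cc2)s1)c1ccccc1`, carries a chloro in place of hydrogen on an aromatic carbon of the benzyl ring and gives 68%. Going by the values given here, the single measured step, a number 3 percentage points higher from compound 1 to compound 2 (within the scatter), shows that the two compounds sit within the scatter of each other, so neither can be called the more active.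

Compound 3, `Cc1ccc(S(=O)(=O)Nc2nnc(SCc3ccccc3)s2)cc1`, has not yet been measured. It differs from compound 1 in one place: methyl in place of hydrogen on an aromatic carbon. Among the compounds with values here, the change sits on the sulfonyl-bearing ring rather than on the benzyl ring, so the one measured step bears on it only in a general way, as a small substituent on an aromatic carbon that left this assay unchanged within the scatter. Within the data shown here, no step in the data points to a shift beyond the scatter, and the account therefore expects compound 3 to behave like compound 1. The expected step is a number 1 percentage points higher from compound 1 to compound 3 (within the scatter). Compound 3 is estimated at 66%, with a range from 52% to 80%.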

Compound 3, a percentage reported as activity, at one concentration (the size of the read-out at that concentration, not a potency): 61%
Beside the measured number, compound 3's estimate is 5 percentage points above it; measured number inside the range.
By their numbers in this assay, from the lowest: compounds 3, 1 and 2 (each within the scatter of the next).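

Going by these compounds alone, the change from phenyl to 4-methylphenyl gives the first measured step at this position, para to a large group: in this assay it is a number 4 percentage points lower from compound 1 to compound 3 (within the scatter). The earlier step, a number 3 percentage points higher from compound 1 to compound 2 (within the scatter), placed chloro on the other aromatic ring and so said nothing directly about this position, whereas here methyl on an aromatic carbon is itself shown to leave the read-out within the scatter of the parent, so this position tolerates methyl without a measurable shift. No measured information is available that would account for the size of this step or tie it to any property of the methyl group.

As far as these compounds go, it remains open whether a different group at this position, such as an amine, a carboxylic acid or a longer chain in place of the methyl, would move the number in this assay beyond the scatter. With one small substituent tested here and a read-out taken at a single concentration, the compounds shown also leave open whether this position matters at all for the effect on these cells.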